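Benzyl extension on the chain of compound 1

The source may hold more compounds than are shown below. What is called first, only, known or untested is meant among the compounds shown, and "the series" means these compounds.

Compound 1 `CCCC(=O)NC[C@@H]1C[C@H]1c1cccc2c1OC(CCC)N2` is the reference point of this small set: in an assay on NIH3T3 cells with melatonin receptor type 1B (Homo sapiens) as the target (a lower number here means a stronger inhibitor, a higher number a weaker inhibitor), compound 1 gives 0.04 nM, the lowest number of the three measured. The nearest is compound 3 `CCCC1Nc2cccc([C@@H]3C[C@H]3CNC(=O)C3CC3)c2O1`, which in this assay gives 0.14 nM, a move of a 3.5-fold higher number from compound 1 to compound 3 (0.54 log units; beyond the scatter). The furthest is compound 2 `CCCC1Nc2cccc([C@@H]3C[C@H]3CNC(=O)C(C)C)c2O1`, which gives 0.28 nM, a move of a 7.0-fold higher number from compound 1 to compound 2 (0.85 log units; beyond the scatter). Between those two, a 2.0-fold lower number from compound 2 to compound 3 (0.30 log units; within the scatter), so compound 2 and compound 3 cannot be ordered.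

All three measured steps exchange the group on the carbonyl carbon. Compound 4 `CCCC(=O)NC[C@@H]1C[C@H]1c1cccc2c1OC(CCCCc1ccccc1)N2` changes a different place: benzyl in place of hydrogen on a saturated chain carbon, three bonds along the chain from a saturated ring carbon. Among the compounds with values here, no measured step touches this chain, so none bears on it directly; the only guide is that the core and amide of compound 1, which carry the best number, are kept intact. A step of no more than modest size, in either direction, is therefore expected, with loss slightly more likely than gain. The estimate for compound 4 is 0.09 nM, ranging from 0.02 nM to 0.5 nM. This estimate corresponds to an expected 2.3-fold higher number from compound 1 to compound 4 (0.35 log units; beyond the scatter).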

Compound 4, inhibition constant: 0.24 nM
Compound 4: middle estimate off by 2.7-fold (0.43 log units), on the low side; measured number inside the range.
By their numbers in this assay, from the lowest: compound 1; then compounds 3, 4 and 2 (each within the scatter of the next).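

Within the data shown here, the step of a 6.0-fold higher number from compound 1 to compound 4 (0.78 log units; beyond the scatter) in this assay is the first reading on the chain rather than on the carbonyl side of the amide. This chain does respond to the added benzyl, yet compound 4 at 0.24 nM shows that the position takes an extension ending in an aromatic ring at only a modest cost. Nothing at hand accounts for the loss.

From the compounds shown here alone, with a single compound changed at this position, it remains open whether the loss follows the aromatic ring or the added length, which a longer unbranched alkyl chain or a cyclohexyl group in place of the phenyl ring would separate. Also open, going by these compounds, is how the chain would respond to an amine or a carboxylic acid at its end.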